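The source may hold more compounds than are shown below. What is called first, only, known or untested is meant among the compounds shown, and "the series" means these compounds.

In a functional assay on MDA-MB-231 cells (Homo sapiens) for antiproliferative activity, read by MTT assay, with a stated time of 24 h (on this read-out higher numbers stand for weaker inhibition and lower numbers for stronger inhibition), compound 1 `COC(=O)c1scc(-c2ccc(NC(=O)c3ccccn3)cc2)c1OC` gives 8250 nM, compound 3 `COC(=O)c1scc(-c2ccc(NC(=O)c3ccc(F)c(Cl)n3)cc2)c1OC` gives 10300 nM, and compound 2 `COC(=O)c1scc(-c2ccc(NC(=O)c3cccc(C(F)(F)F)c3)cc2)c1OC` gives 24600 nM. Compound 2 therefore has the highest number of the three and is the weakest inhibitor in this small set. Compound 4 `COC(=O)c1scc(-c2ccc(NC(=O)c3cccc(OC(F)(F)F)c3)cc2)c1OC` differs from compound 2 in one group, with trifluoromethoxy in place of trifluoromethyl on an aromatic carbon, meta to a large group: trifluoromethoxy in place of trifluoromethyl on an aromatic carbon.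

Within the data shown here, no measured pair tests this exact swap. The closest evidence comes from replacing the whole ring on the carbonyl carbon. That gave a 3.0-fold higher number from compound 1 to compound 2 (0.47 log units; beyond the scatter) and a 2.4-fold lower number from compound 2 to compound 3 (0.38 log units; beyond the scatter), both modest, while a 1.2-fold higher number from compound 1 to compound 3 (0.10 log units; within the scatter) stayed within the scatter. Even the larger of these whole-ring changes, a 3.0-fold higher number from compound 1 to compound 2 (0.47 log units; beyond the scatter), was modest, and here the ring itself stays, so no step beyond the scatter is expected in this assay. The expected step is a 1.1-fold lower number from compound 2 to compound 4 (0.05 log units; within the scatter). For compound 4 the estimate is 22000 nM, with an expected range from 10000 nM to 45000 nM.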

Compound 4, half-maximal inhibitory concentration: 7540 nM
Estimate against measurement, compound 4: 2.9-fold (0.47 log units) above, and the stated range ends above it.
By their numbers in this assay, from the lowest: compounds 4, 1 and 3 (each within the scatter of the next); then compound 2.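

With the ring kept, the swap of trifluoromethyl for trifluoromethoxy on this aromatic carbon, meta to a large group, adds only one oxygen, yet in this assay it gives a 3.3-fold lower number from compound 2 to compound 4 (0.51 log units; beyond the scatter), a modest step beyond the scatter. The weak number of compound 2 therefore does not come with this ring alone, since compound 4 keeps that ring and still falls within the scatter of compounds 1 and 3. No measurement shown here explains why this one-atom change has this effect.

From the compounds shown here alone, it remains open how this position responds to other groups, such as a methyl group, a chlorine atom or an amine. It is also unclear whether trifluoromethoxy would give a similar step on a pyridine ring like that of compound 1.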